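Bromo for Methyl on the Outer Aryl Ring of Compound 1

This account rests on a few compounds, and the source may have more. Where it says the series, first, only, none or still open, it means among the compounds named here.

Compound 1 `C=CCn1c(=O)/c(=C\c2cccc(C)c2)[nH]c(=O)/c1=C\c1ccccc1OC` is the weaker of the two compounds that returned a number in a functional assay on K562 cells (Homo sapiens) for cytotoxicity, read by CCK-8 assay, with a stated time of 72 h; a lower number here means a stronger inhibitor, a higher number a weaker inhibitor; in that assay compound 1 gives 8800 nM. Compound 2 `COc1ccccc1/C=c1\c(=O)[nH]/c(=C/c2ccccc2Cl)c(=O)n1C` gives 110 nM, a lower number than compound 1 by a margin beyond the scatter. Compound 3 `C=CCn1c(=O)/c(=C\c2ccc(F)c(Br)c2)[nH]c(=O)/c1=C\c1ccccc1OC` is recorded in this assay as "not active" (no number reported), without a number. Compound 4 `C=CCn1c(=O)/c(=C\c2cccc(Br)c2)[nH]c(=O)/c1=C\c1ccccc1OC` is compound 1 with the change (bromo in place of methyl on an aromatic carbon). Going by the values given here, no measured step of this kind exists. A step no larger than the scatter, or a weakening, is expected for compound 4, since compound 3, which also carries bromo, is recorded as "not active" (no number reported). The step to compound 4 is estimated as a 1.4-fold higher number from compound 1 to compound 4 (0.13 log units; within the scatter). Compound 4 is expected at 12000 nM, between 4000 nM and 40000 nM.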

Compound 4, half-maximal inhibitory concentration: 2400 nM
For compound 4 the middle estimate is 5.0-fold (0.70 log units) above the measured one; the whole stated range lies above it.
By their numbers in this assay, from the lowest: compound 2; then compound 4; then compound 1.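

In this assay bromo in place of methyl on this aromatic carbon gives a 3.7-fold lower number from compound 1 to compound 4 (0.56 log units; beyond the scatter) and so shows that the position tolerates the change, with a stronger result rather than a loss. Bromo here does not by itself bring the "not active" record of compound 3, which carries a further fluoro on the same ring. No measurement at hand accounts for the step. Open, as far as these compounds go, is how an amine or a carboxylic acid would read on this carbon, and whether chloro would follow bromo here.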